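The source may report more compounds than this note shows. Statements on the series, on what has been measured and on what is new or still open speak of the compounds shown alone.

The measured compounds:
Compound 1 `CC(=O)OCOC(=O)C1=C(S[C@@H]2CN[C@H](C(=O)Nc3cccc(C(=O)OCOC(C)=O)c3)C2)[C@H](C)[C@@H]2[C@@H]([C@@H](C)O)C(=O)N12`: in an ADME assay for metabolic stability, read by LC-MS, with a stated time of 3 h, at pH 6.5, tested at 50 uM (on this read-out higher numbers stand for a more stable compound and lower numbers for a less stable compound), compound 1 gives > 95%, which is a limit of the assay.
Compound 2 `C[C@@H](O)[C@H]1C(=O)N2C(C(=O)OCOC(=O)C(C)(C)C)=C(S[C@@H]3CN[C@H](C(=O)Nc4cccc(C(=O)OCOC(=O)C(C)(C)C)c4)C3)[C@H](C)[C@H]12`: in this assay compound 2 gives > 95%, again a limit of the assay.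
Compound 3 `C[C@@H](O)[C@H]1C(=O)N2C(C(=O)OCOC(=O)C(C)(C)C)=C(S[C@@H]3CN[C@H](C(=O)Nc4cccc(C(=O)O)c4)C3)[C@H](C)[C@H]12`: in this assay compound 3 gives > 95%, also a limit of the assay.

Compound 3 therefore stands at the limit of this assay, where every value shown sits; only a limit, not a number, is known for it. Within the data shown here, the single one-place step among the measured compounds is a step that the two limits leave unreadable from compound 2 to compound 3: both of its ends are limits, so its size cannot be read. Compound 4 `C[C@@H](O)[C@H]1C(=O)N2C(C(=O)OCOC(=O)C3CCCCC3)=C(S[C@@H]3CN[C@H](C(=O)Nc4cccc(C(=O)O)c4)C3)[C@H](C)[C@H]12` differs from compound 3 in one place: cyclohexyl in place of tert-butyl on a carbonyl carbon. The change swaps (tert-butyl)carbonyl for cyclohexylcarbonyl and leaves the rest of the molecule untouched. Among the measured compounds shown here, no measured step touches this position, so the only guide is the limit of > 95% in this assay, at which 3 of the 3 values shown sit; because of the limit of > 95% in this assay, at which 3 of the 3 values shown sit, every compound tested here in this assay has reached the limit. The step from compound 3 to compound 4 is therefore expected to be unreadable, estimated as a step that the limit leaves unreadable from compound 3 to compound 4. Compound 4 is expected to give 97% in this assay, estimated between 88% and 100%, most likely reported again as a limit.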

Compound 4, percent of the compound remaining: > 95%
Compound 4: no number, only a limit (the forecaster's own chance of this, stated with the estimate: 85%); the middle value lies beyond the limit too.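

In this assay compound 4 gives > 95%, which is a limit of the assay and not a number. Among these compounds, no step can therefore be read between compound 3 and compound 4. How far any of these changes shifts the percent of compound remaining stays open, because the results all stop at the same point: the limit of > 95% in this assay, at which 4 of the 4 values shown sit.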